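The source may hold more compounds than are shown below. What is called first, only, known or untested is meant among the compounds shown, and "the series" means these compounds.

Of the compounds shown here, three of one shared core have been measured in a functional assay on HepG2 cells (Homo sapiens) for antiproliferative activity, read by MTT assay, with a stated time of 48 h; on this read-out higher numbers stand for weaker inhibition and lower numbers for stronger inhibition. Compound 1 `CCCCCCCCCCCCOc1ccc(C(=O)/C=C/c2c(/C=C/c3ccc(OC)cc3)cc(OC)cc2OC)cc1` gives 11.6 ug/mL. Compound 2 `COc1ccc(/C=C/c2cc(OC)cc(OC)c2/C=C/C(=O)c2cccc(Br)c2)cc1` gives 13 ug/mL, and compound 3 `COc1ccc(/C=C/c2cc(OC)cc(OC)c2/C=C/C(=O)c2ccc(Br)cc2)cc1` gives 12.9 ug/mL. Compound 3 thus has the second highest of the three numbers, but all three lie within the usual scatter of one another, so nothing separates them. Among the compounds with values here, the only single-point comparison among the measured compounds is a 1.0-fold lower number from compound 2 to compound 3 (0.00 log units; within the scatter), a change of the bromo group's place on the aryl ring that left the number where it was.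

Compound 4 `COc1ccc(/C=C/c2cc(OC)cc(OC)c2/C=C/C(=O)c2ccc(C)c(C)c2)cc1` is not yet measured. Its difference from compound 3 is 3,4-dimethylphenyl in place of 4-bromophenyl on a carbonyl carbon. Within the data shown here, no measured pair swaps a bromo group for methyl groups, so the one step available, from compound 2 to compound 3, bears on compound 4 only loosely: it shows that reshaping this aryl ring did not move the read-out beyond the scatter. On that basis the expectation for compound 4 is no step beyond the scatter, and the estimated shift is a 1.0-fold higher number from compound 3 to compound 4 (0.00 log units; within the scatter). The estimated value for compound 4 is therefore 13 ug/mL, expected to fall between 6 ug/mL and 30 ug/mL.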

Compound 4, half-maximal inhibitory concentration: 0.2 ug/mL
Estimate against measurement, compound 4: 65-fold (1.81 log units) above, and the stated range ends above it.
By their numbers in this assay, from the lowest: compound 4; then compounds 1, 3 and 2 (each within the scatter of the next).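

In this assay, the aryl group on the carbonyl carbon proves able to move the read-out a long way: 3,4-dimethylphenyl in place of 4-bromophenyl gives a 65-fold lower number from compound 3 to compound 4 (1.81 log units; beyond the scatter), and 3,4-dimethylphenyl in place of 3-bromophenyl gives a 65-fold lower number from compound 2 to compound 4 (1.81 log units; beyond the scatter). The earlier step, a 1.0-fold lower number from compound 2 to compound 3 (0.00 log units; within the scatter), changed only where the bromo group sat on this ring, so the flat picture it gave holds for those two bromo compounds and not for this position as a whole. The swap removes the bromine and adds two methyl groups in a single change, and no measurement shown here tells what lies behind the large step.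

The compounds shown leave open whether one methyl group would be enough, or whether both are needed, and whether an unsubstituted phenyl ring would sit with the bromo compounds or with compound 4. They also leave open how other groups on this ring would read, such as a chloro group, a methoxy group or a longer chain like ethyl.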